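This account rests on a few compounds, and the source may have more. Where it says the series, first, only, none or still open, it means among the compounds named here.

The series shares one core, shown in compound 1 `CS(=O)(=O)c1ccc(C(=O)Nc2ccc(Cl)c(-c3nnc4c(Cl)cccn34)c2)c(Cl)c1`, which in a functional assay on MDA-MB-231 cells (Homo sapiens) for antiproliferative activity, read by MTT assay, with stated times of 72 h and 4 h (on this read-out lower numbers stand for stronger inhibition and higher numbers for weaker inhibition), gives 37200 nM. Compound 2 `Cc1nc(C(=O)Nc2ccc(Cl)c(-c3nnc4c(Cl)cccn34)c2)cs1` reaches only the assay limit, > 100000 nM, in this assay. Compound 3 `O=C(Nc1ccc(Cl)c(-c2nnc3c(Cl)cccn23)c1)c1ccc(Cl)cc1` also sits at the limit, > 100000 nM, in this assay. The step that the two limits leave unreadable from compound 2 to compound 3 cannot be read, since both ends rest at the limit of > 100000 nM in this assay, at which 2 of the 3 values shown sit. Compound 4 `O=C(Nc1ccc(Cl)c(-c2nnc3c(Cl)cccn23)c1)c1cccnc1Cl` differs from compound 3 by 2-chloropyridin-3-yl in place of 4-chlorophenyl on a carbonyl carbon. For the measured compounds named here, no measured step covers this change; the only readable number in the set belongs to compound 1, while compound 3 gives no number at all. Compound 4 is therefore expected to remain near the limit, with an estimated 100000 nM, from 40000 nM to 300000 nM. The step of a number no higher from compound 3 to compound 4 (the limit leaves the size open) in this assay is thus an estimate only.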

Compound 4, half-maximal inhibitory concentration: 89700 nM
The estimate for compound 4 lay 1.1-fold (0.05 log units) above the measured number; the range from low to high includes it.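

At this carbonyl carbon, 2-chloropyridin-3-yl gives a readable number in this assay, where 4-chlorophenyl and 2-methyl-1,3-thiazol-4-yl give none. The exchange for 4-chlorophenyl gives an at least 1.1-fold lower number from compound 3 to compound 4 (0.04 log units; that floor lies within the scatter), and the exchange for 2-methyl-1,3-thiazol-4-yl gives an at least 1.1-fold lower number from compound 2 to compound 4 (0.04 log units; that floor lies within the scatter). Both are floors that stay within the scatter, and the true sizes cannot be read because the two starting compounds rest at a limit: the limit of > 100000 nM in this assay, at which 2 of the 4 values shown sit.

Still open, from the compounds shown here alone, is whether a pyridine ring carrying an amine or a carboxylic acid in place of the chlorine, on a carbonyl carbon, moves the number beyond the scatter.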